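Swapping a small ring for a larger one on a sulfonamide

The compounds below may be only part of what the source reports. "The series", "measured", "known", "first", "only" and "open" are said of these compounds alone.

Compound 1, `O=C(NO)c1ccc(CN(C2CC2)S(=O)(=O)c2cc(F)c(F)c(F)c2F)cc1`, was tested in an assay on Sf9 cells for inhibition of histone deacetylase 8 (Homo sapiens), read by fluorescence and mobility shift assay; on this read-out lower numbers stand for stronger inhibition and higher numbers for weaker inhibition. In this assay compound 1 gives > 1000 nM, which is a limit of the assay rather than a number; this is the limit of > 1000 nM in this assay, at which 1 of the 2 values shown sits. A second compound with the same core, compound 2, `COc1cc(C(=O)NO)ccc1CN(C(C)C)S(=O)(=O)c1cc(F)c(F)c(F)c1F`, was also tested, and in this assay compound 2 gives 474 nM. Compound 3, `O=C(NO)c1ccc(CN(C2CCCC2)S(=O)(=O)c2cc(F)c(F)c(F)c2F)cc1`, differs from compound 1 in one place: cyclopentyl in place of cyclopropyl on a sulfonamide nitrogen. Among the measured compounds shown here, no measured pair with such a change is known here, so no step can be quoted for it. From compound 1 to compound 3 the expected step in this assay is a step that the limit leaves unreadable from compound 1 to compound 3, which is not beyond the scatter in either direction. For compound 3 in this assay the estimated value is 1500 nM, within a range from 400 nM to 6000 nM, with a fair chance that only a limit is reported again.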

Compound 3, half-maximal inhibitory concentration: > 1000 nM
Compound 3 ended at the assay's limit (the forecaster's own chance of this, stated with the estimate: 55%); the middle value is on the limit's open side.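

For compound 1 and compound 3 both results are limits of the assay, so no step can be read between them: the limit of > 1000 nM in this assay, at which 2 of the 3 values shown sit.

As far as these compounds go, whether cyclopentyl in place of cyclopropyl on a sulfonamide nitrogen changes inhibition in this assay at all, and in which direction, stays open.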